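Hydroxypropyl side chain on the shared core

The compounds below may be only part of what the source reports. "The series", "measured", "known", "first", "only" and "open" are said of these compounds alone.

In a functional assay on HL-60 cells (Homo sapiens) for cytotoxicity, read by MTT assay, with a stated time of 24 h (on this read-out higher numbers stand for weaker inhibition and lower numbers for stronger inhibition), compound 2 `CCOC(=O)C(C)Oc1c(Br)cc(Br)cc1Oc1ccc(Br)cc1Br` gives 35.7 ug/mL. Compound 3 `CC(C)(C)OC(=O)N1CCN(CCCCCOc2c(Br)cc(Br)cc2Oc2ccc(Br)cc2Br)CC1` gives 32.1 ug/mL and compound 1 `OCCOc1c(Br)cc(Br)cc1Oc1ccc(Br)cc1Br` gives 28.2 ug/mL; the three figures sit within the usual scatter of one another, so no order among them is secure. Compound 4 `OCCCOc1c(Br)cc(Br)cc1Oc1ccc(Br)cc1Br` differs from compound 2 in one place: 3-hydroxypropyl in place of 1-(ethoxycarbonyl)ethyl on an oxygen on an aromatic ring. Within the data shown here, the one measured step that bears on this exchange is a 1.3-fold higher number from compound 1 to compound 2 (0.10 log units; within the scatter), which swapped a closely related short hydroxyalkyl chain for the same ester-bearing group and stayed within the scatter. The reverse kind of exchange is therefore expected to move the number little, and the expected step, a 1.2-fold lower number from compound 2 to compound 4 (0.09 log units; within the scatter), stays within the scatter. Compound 4 is estimated at 29 ug/mL, with a range from 17 ug/mL to 50 ug/mL.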

Compound 4, half-maximal inhibitory concentration: 29.9 ug/mL
For compound 4 the middle estimate is 1.0-fold (0.01 log units) below the measured one; measured number inside the range.
By their numbers in this assay, from the lowest: compounds 1, 4, 3 and 2 (each within the scatter of the next).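

In this assay, the side chain on the oxygen on the aromatic ring takes 3-hydroxypropyl in place of 1-(ethoxycarbonyl)ethyl without a step beyond the scatter (a 1.2-fold lower number from compound 2 to compound 4 (0.08 log units; within the scatter)). Hydroxymethyl in place of hydroxy on the saturated chain carbon is likewise within the scatter (a 1.1-fold higher number from compound 1 to compound 4 (0.03 log units; within the scatter)), so 2-hydroxyethyl and 3-hydroxypropyl are not told apart at this position. No evidence bears on these results.

Open, going by these compounds, is whether a carboxylic acid or a primary amine at the end of this chain would give a step beyond the scatter.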